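Trading 4-aminophenyl for 2-chlorophenyl on the shared core

A few compounds are considered here, and "the series" means these few. Any claim that something is new, unique, unknown or untested is made for them only; others in the source may bear on it.

Within the data shown here, in an ADME assay on HepG2 cells (Homo sapiens) for cytotoxicity, read by fluorescence and resazurin assay, with a stated time of 24 h (on this read-out higher numbers stand for lower toxicity in this test and lower numbers for higher toxicity in this test), compound 2 `Nc1ccc(-c2nnc(SC3=CS(=O)(=O)c4ccccc43)o2)cc1` gives 24000 nM and so lies within the scatter of compound 1 `O=S1(=O)C=C(Sc2nnc(C3CCCCC3)o2)c2ccccc21` at 15000 nM as the only other number so far. Compound 3 `O=S1(=O)C=C(Sc2nnc(-c3ccccc3Cl)o2)c2ccccc21` carries 2-chlorophenyl in place of 4-aminophenyl on an aromatic carbon of the shared core. Among the measured compounds shown here, the one measured step that bears on this is a 1.6-fold higher number from compound 1 to compound 2 (0.20 log units; within the scatter) and it involves the same 4-aminophenyl, so no step beyond the scatter is expected in this assay here. The expected change is a 1.3-fold lower number from compound 2 to compound 3 (0.12 log units; within the scatter) and stays within the scatter. Compound 3 is estimated at 18000 nM with a range from 8000 nM to 40000 nM for repeated measurements.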

Compound 3, half-maximal cytotoxic concentration: 25000 nM
For compound 3 the middle estimate is 1.4-fold (0.14 log units) below the measured one; the range from low to high includes it.
By their numbers in this assay, from the lowest: compounds 1, 2 and 3 (each within the scatter of the next).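

In this assay the exchange of 4-aminophenyl for 2-chlorophenyl gives (a 1.0-fold higher number from compound 2 to compound 3 (0.02 log units; within the scatter)) and the exchange of cyclohexyl for 2-chlorophenyl gives (a 1.7-fold higher number from compound 1 to compound 3 (0.22 log units; within the scatter)). This place on the shared core has thus taken three different groups without a step beyond the scatter, even where the hydrogen-bond donor and acceptor counted on 4-aminophenyl leave and chlorine enters. Nothing available here accounts for this result. From the compounds shown here alone, whether a carboxylic acid or a longer alkyl chain at this place would also stay within the scatter remains open, as does the effect of any change elsewhere on the shared core.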